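The source may report more compounds than this note shows. Statements on the series, on what has been measured and on what is new or still open speak of the compounds shown alone.

Measured so far in a functional assay on UACC-257 cells (Homo sapiens) for inhibition, read by sulforhodamine B assay, with a stated time of 48 h; a higher number here means a weaker inhibitor of growth, a lower number a stronger inhibitor of growth:
- compound 1 `O=C(Cc1csc2nc(-c3ccc(Br)cc3)cn12)N/N=C/c1ccccc1O` gives 11500 nM
- compound 2 `COc1cccc(OC)c1/C=N/NC(=O)Cc1csc2nc(-c3ccc(Br)cc3)cn12` gives 97700 nM

Compound 1 holds the lower of these two numbers and is the stronger growth inhibitor of the pair. Compound 3 `O=C(Cc1csc2nc(-c3ccc(Br)cc3)cn12)N/N=C/c1ccc(Cl)cc1Cl` has not yet been measured. It differs from compound 1 on a carbon with a double bond to nitrogen, where 2,4-dichlorophenyl takes the place of 2-hydroxyphenyl 2,4-dichlorophenyl in place of 2-hydroxyphenyl on a carbon with a double bond to nitrogen and the rest of the structure stays the same.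

For the measured compounds named here, only one measured step bears on this change. In it, 2,6-dimethoxyphenyl replaces 2-hydroxyphenyl at the same place, and the result is an 8.5-fold higher number from compound 1 to compound 2 (0.93 log units; beyond the scatter) as a modest step. That step also gives up the 2-hydroxyphenyl and moves towards a higher number. Going by the values given here, it is a single step, however, and no measured compound carries 2,4-dichlorophenyl. A rise smaller than that step is therefore expected in this assay with wide uncertainty. The expected move is a 1.9-fold higher number from compound 1 to compound 3 (0.28 log units; within the scatter) as an estimate. Compound 3 is estimated at 22000 nM with 7000 nM to 80000 nM as the expected range.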

Compound 3, concentration for total growth inhibition: > 100000 nM
Compound 3: only a limit was reported; the forecaster's own chance of this, stated with the estimate: 15%; at least 4.5-fold (0.65 log units) between middle value and limit.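

In this assay compound 3 gives > 100000 nM as a limit and not a number. With a second replacement of 2-hydroxyphenyl on a carbon with a double bond to nitrogen, the rise no longer rests on 2,6-dimethoxyphenyl alone: 2,4-dichlorophenyl, which has 0 hydrogen-bond donors and 0 hydrogen-bond acceptors, gives an at least 8.6-fold higher number from compound 1 to compound 3 (0.93 log units; beyond the scatter) and leaves compound 1 with the lowest number of the three, with no compound shown going against this. The two replacements cannot be put in order, the reading being an at least 1.0-fold higher number from compound 2 to compound 3 (0.01 log units; that floor lies within the scatter) and no more than a floor, and the size of both new steps is tied to the ceiling of the assay: the limit of > 100000 nM in this assay, at which 1 of the 3 values shown sits.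

Going by these compounds, how far compound 3 lies beyond its limit stays open, and so does whether the hydroxyl group of compound 1 is what holds its number down, since both replacements also bring other groups onto the ring. A plain phenyl or an aminophenyl at this place would bear on that question, and the compounds shown say nothing about either group.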